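Carbamate chain variation and plasma unbound fraction

A few compounds are considered here, and "the series" means these few. Any claim that something is new, unique, unknown or untested is made for them only; others in the source may bear on it.

Measured so far:
compound 1 `CCCCN(C)C(=O)OCc1c(-c2ccc(O[C@H]3CCC[C@H](C(=O)O)C3)c(C)n2)nnn1C` — 0.134
compound 2 `Cc1cc(-c2nnn(C)c2COC(=O)N(C)CCC(C)C)ccc1O[C@H]1CCC[C@H](C(=O)O)C1` — 0.018
compound 3 `Cc1nc(-c2nnn(C)c2COC(=O)N(C)CC2CCC2)cnc1O[C@H]1CCC[C@H](C(=O)O)C1` — 0.073

In an ADME assay on the whole organism (plasma, Mus musculus, strain CD-1) for protein binding, read by LC-MS, with a stated time of 24 h (a lower number here means a smaller unbound share, a higher number a larger unbound share of the compound), compound 1 gives 0.134, the highest of the three numbers. Compound 3 sits close to it, within the scatter, while compound 2 lies well beyond the scatter on the lower side, so compound 1 is not singled out from compound 3 by these data.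

Compound 4 `Cc1nc(-c2nnn(C)c2COC(=O)N(C)CC2CCC2)ccc1O[C@H]1CCC[C@H](C(=O)O)C1` keeps the core of compound 1 and alters only the carbamate chain: cyclobutyl in place of propyl on a saturated chain carbon bound to an amide-type nitrogen. For the measured compounds named here, no measured pair shows this change on its own. Compound 3 carries the same cyclobutylmethyl chain on a different core and gives 0.073, within the scatter of compound 1.

The step from compound 1 to compound 4 is therefore expected to be small, a 1.3-fold lower number from compound 1 to compound 4 (0.13 log units; within the scatter), not clearly beyond the scatter. For compound 4 the unbound fraction is estimated at 0.1, within 0.05 to 0.18.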

Compound 4, unbound fraction: 0.1
Estimate against measurement, compound 4: no gap at the digits printed, within the range that was stated.
By their numbers in this assay, from the lowest: compound 2; then compounds 3, 4 and 1 (each within the scatter of the next).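

For the compounds shown here, on the core of compound 1, in this assay, cyclobutyl in place of propyl on a saturated chain carbon bound to an amide-type nitrogen gives a 1.3-fold lower number from compound 1 to compound 4 (0.13 log units; within the scatter) and provides the first single-place step. At this place, a four-membered ring in the chain therefore leaves the two compounds indistinguishable in unbound fraction. No evidence on the cause accompanies this step.

On these data alone, whether an amine or a hydroxyl group on this chain would give a step beyond the scatter stays open. Also open, as far as these compounds go, is whether butyl to cyclobutylmethyl reads the same on other cores.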